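Growing the nitrogen substituent of compound 1

The source may report more compounds than this note shows. Statements on the series, on what has been measured and on what is new or still open speak of the compounds shown alone.

Compound 1, `CCC(C)n1nc(C)cc1NC(=O)Cn1nnc(-c2ccccc2)n1`, in an assay on HEK293 cells for activation of Kir3.1/Kir3.2 (Homo sapiens), read by thallium flux; a higher number here means a larger maximal response, a lower number a smaller maximal response: > 69%
Compound 2, `CC1(c2cc(NC(=O)Cn3nnc(-c4ccccc4)n3)n(C3CCCCC3)n2)CC1`, in this assay: > 10%
Compound 3, `O=C(Cn1nnc(-c2ccccc2)n1)Nc1cc(C2(C(F)(F)F)CC2)nn1C1CCCCC1`, in this assay: "not active" (no number reported)

The value for compound 1 is a limit of the assay rather than a number; it stands at the limit of > 69% in this assay, at which 1 of the 3 values shown sits. The value for compound 2 is also a limit, the one described as the limit of > 10% in this assay, at which 1 of the 3 values shown sits. Compound 3 gave no number at all. Among these three, compound 1 is thus the only one whose reading sits at the higher limit.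

Compound 4, `Cc1cc(NC(=O)Cn2nnc(-c3ccccc3)n2)n(CC2CCCCC2)n1`, has not yet been measured. It differs from compound 1 in one place: cyclohexylmethyl in place of sec-butyl on an aromatic nitrogen. The methyl group on the shared core is kept.

Among the measured compounds shown here, no two measured compounds here differ in a single place, so no measured step is available to lean on. Compound 2 and compound 3 carry a ring directly on the same aromatic nitrogen and show lower or no responses, but they also differ elsewhere, so what they show cannot be assigned to the nitrogen group alone. A step of moderate size downward, beyond the usual scatter, is what is expected for a number at least 19 percentage points lower from compound 1 to compound 4 (beyond the scatter). Compound 4 is therefore estimated to reach 50% in this assay, within a range from 15% to 85%.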

Compound 4, largest response reached (Emax), in percent of the reference or control that the assay uses: 77%
Estimate against measurement, compound 4: 27 percentage points below; measured number inside the range.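

Compound 1 has only a limit of the assay and no number, and the step from compound 1 to compound 4 cannot be read. The compounds shown leave open whether cyclohexylmethyl in place of sec-butyl raises, lowers or leaves unchanged the response in this assay.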